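Thiophene for acetylphenyl at the aryl position of the core

A few compounds are considered here, and "the series" means these few. Any claim that something is new, unique, unknown or untested is made for them only; others in the source may bear on it.

Compound 3 `CC(=O)c1ccc(-c2cn3ccnc3c(-c3ccc4ncn(C5CCCCC5)c4c3)n2)cc1` carries a 4-acetylphenyl on the shared core; in a functional assay on SN12C cells (Homo sapiens) for inhibition, read by sulforhodamine B assay, with a stated time of 48 h, tested at 10 uM (a higher number here means more inhibition at the concentration tested (going by the name of the read-out), a lower number less inhibition), compound 3 gives 6.33%, the lowest of the three numbers. Compound 1 `c1ccc(-c2cn3ccnc3c(-c3ccc4ncn(C5CCCCC5)c4c3)n2)cc1`, with hydrogen at that position, gives 28.8%, and compound 2 `O=Cc1ccc(-c2cn3ccnc3c(-c3ccc4ncn(C5CCCCC5)c4c3)n2)cc1`, with formyl, gives 20.7%. The steps into compound 3 run downward: a number 22.5 percentage points lower from compound 1 to compound 3 (beyond the scatter) and a number 14.4 percentage points lower from compound 2 to compound 3 (beyond the scatter), while a number 8.1 percentage points lower from compound 1 to compound 2 (within the scatter).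

Compound 4 `c1csc(-c2cn3ccnc3c(-c3ccc4ncn(C5CCCCC5)c4c3)n2)c1` is not yet measured. The change is thiophen-2-yl in place of 4-acetylphenyl on an aromatic carbon. The acetyl that marks compound 3 as lowest is removed, so the steps from compound 1 and compound 2 to compound 3 bear on it in reverse; nothing measured here shows how thiophen-2-yl compares with an unsubstituted phenyl, so the size of that part is open. An upward step, a number 18.7 percentage points higher from compound 3 to compound 4 (beyond the scatter), is expected, returning toward the range of compound 1 because of 28.8%. Compound 4 is therefore estimated at 25%, between 10% and 40%.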

Compound 4, a percentage reported as inhibition, at one concentration (the size of the read-out at that concentration, not a potency): 2.84%
The estimate for compound 4 lay 22.2 percentage points above the measured number; the measured number lies below the stated range.
By their numbers in this assay, from the lowest: compounds 4 and 3 (each within the scatter of the next); then compounds 2 and 1 (each within the scatter of the next).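

In this assay, compound 3 and compound 4 cannot be told apart: a number 3.5 percentage points lower from compound 3 to compound 4 (within the scatter). Thiophen-2-yl carries no carbonyl, yet the number falls with a number 26 percentage points lower from compound 1 to compound 4 (beyond the scatter) and with a number 17.9 percentage points lower from compound 2 to compound 4 (beyond the scatter), so a carbonyl on the aryl group is not required for a low number at this position, and thiophen-2-yl does not behave like the unsubstituted phenyl of compound 1. No measured evidence here accounts for this result.

The compounds shown leave open whether the loss follows the sulfur or the five-membered ring, which furan-2-yl, thiophen-3-yl or pyridin-3-yl in the same place could separate. They also leave open whether any para substituent on the phenyl, such as an amine or a carboxylic acid, can lift the number beyond that of compound 1.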